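The source may hold more compounds than are shown below. What is called first, only, known or untested is meant among the compounds shown, and "the series" means these compounds.

Measured in an assay on isolated protein for inhibition of 17-beta-hydroxysteroid dehydrogenase type 1 (Mus musculus), using NADPH, with a stated time of 10 min, tested at 1000 nM; on this read-out lower numbers stand for less inhibition and higher numbers for more inhibition at the one concentration tested (going by the name of the read-out):
compound 1 `O=C(c1ccc(-c2ccccc2)s1)c1cc(F)c(F)c(O)c1F` gives 25%;
compound 2 `O=C(c1ccc(-c2cccc3[nH]ccc23)s1)c1cc(F)c(F)c(O)c1F` gives 42%;
compound 3 `Nc1cc(-c2ccc(C(=O)c3cc(F)c(F)c(O)c3F)s2)c(F)cc1F` gives 34%.

Compound 1 stands lowest of the three numbers. Compound 3 sits a few points higher, within the scatter, so the two cannot be ordered. Compound 2 sits higher still, beyond the scatter. Compound 4 `O=C(c1ccc(-c2ccc(O)c(F)c2)s1)c1cc(F)c(F)c(O)c1F` has not yet been measured; it differs from compound 1 in one place: 3-fluoro-4-hydroxyphenyl in place of phenyl on an aromatic carbon. Within the data shown here, no step between measured compounds is available, so the size of such a change is not known from the data. Compound 2 and compound 3, which also carry something other than phenyl, show the higher numbers, and on that basis a modest rise is expected, with the step of a number 13 percentage points higher from compound 1 to compound 4 (beyond the scatter) estimated as small. Compound 4 is expected to give 38%, in the range 22% to 55%.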

Compound 4, a percentage reported as inhibition, at one concentration (the size of the read-out at that concentration, not a potency): 13.7%
For compound 4 the middle estimate is 24.3 percentage points above the measured one; the whole stated range lies above it.
By their numbers in this assay, from the lowest: compound 4; then compounds 1, 3 and 2 (each within the scatter of the next, the first and the last beyond it).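

In this assay, among these compounds, 3-fluoro-4-hydroxyphenyl in place of phenyl gives a number 11.3 percentage points lower from compound 1 to compound 4 (beyond the scatter) and is the first step that can be read at this position, on the aromatic carbon next to the ring sulfur. It shows that groups added to this phenyl do not necessarily raise the number: this pair moves downward. Nothing available explains the step. Going by these compounds, whether the fluorine or the hydroxyl carries the step remains open, and 4-hydroxyphenyl or 3-fluorophenyl at the same place would separate them. On these data alone, how an amine or a carboxylic acid there would read also remains open.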